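This account rests on a few compounds, and the source may have more. Where it says the series, first, only, none or still open, it means among the compounds named here.

Measured compounds:
- compound 1, `C=CC(=O)N1CC[C@H](N2C(=O)N(c3ccccc3)Cc3cnc(Nc4cccc(N5CCN(C)CC5)c4)nc32)C1`, 746 ng.h/mL
- compound 2, `C=CC(=O)N1CC[C@H](N2C(=O)N(c3ccccc3)Cc3cnc(Nc4ccc(N5CCN(C)CC5)cc4)nc32)C1`, 857 ng.h/mL

Of the compounds shown here, two have been measured in an ADME assay on the whole organism (plasma, strain Sprague-Dawley) for pharmacokinetics, with Rattus norvegicus as the target, read by LC-MS, at a dose of 5 mg/kg by the intravenous route; on this read-out higher numbers stand for higher exposure at the dose given and lower numbers for lower exposure. Compound 1 gives 746 ng.h/mL in this assay. Compound 2 gives 857 ng.h/mL in this assay, the higher of the two numbers, though its gap to compound 1 lies within the scatter, so the two values cannot be told apart.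

Compound 3, `C=CC(=O)N1CC[C@H](N2C(=O)N(c3ccccc3)Cc3cnc(Nc4ccccc4)nc32)C1`, has not yet been measured in this assay. It differs from compound 2 in one place: hydrogen in place of 4-methylpiperazin-1-yl on an aromatic carbon. Within the data shown here, no step between measured compounds shows what removing this group does to exposure; the two measured compounds only show that moving it from one aromatic carbon to another leaves the number within the scatter.

Among the measured compounds shown here, with no measured step to rest on, the step from compound 2 to compound 3 is expected to be a 1.1-fold lower number from compound 2 to compound 3 (0.03 log units; within the scatter), which is no change beyond the scatter. Compound 3 is therefore estimated at 800 ng.h/mL in this assay, with a wide range from 250 ng.h/mL to 2500 ng.h/mL.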

Compound 3, area under the concentration-time curve: 2030 ng.h/mL
Beside the measured number, compound 3's estimate is 2.5-fold (0.40 log units) below it; low and high end bracket the measured number.
By their numbers in this assay, from the lowest: compounds 1 and 2 (each within the scatter of the next); then compound 3.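

In this assay, replacing the 4-methylpiperazin-1-yl group with hydrogen on the aromatic carbon gives a 2.4-fold higher number from compound 2 to compound 3 (0.37 log units; beyond the scatter), and the same change at the group's other placement gives a 2.7-fold higher number from compound 1 to compound 3 (0.43 log units; beyond the scatter). The earlier pair showed only that the two placements of the group could not be told apart, whereas these steps show that the bare ring stands apart from both, with a modest gain in exposure at the dose given that lies beyond the scatter. The data shown offer nothing that explains this difference in exposure.

The compounds shown do not tell whether the lower exposure goes with the whole 4-methylpiperazin-1-yl group or only with part of it, and a morpholine ring, a dimethylamino group or a plain methoxy group on the same aromatic carbon could help separate these possibilities. They also leave open whether the same replacement would give a step of similar size with a different group in place of the phenyl on the shared core, or with the acrylamide changed to a saturated propionamide.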